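A few compounds are considered here, and "the series" means these few. Any claim that something is new, unique, unknown or untested is made for them only; others in the source may bear on it.

Compound 1 `N#Cc1ccc(C2OCC(C/C=C\CCC(=O)O)C(c3cccnc3)O2)cc1` in an assay for inhibition of prostacyclin synthase (Homo sapiens), using microsomes (a lower number here means a stronger inhibitor, a higher number a weaker inhibitor), gives > 100000 nM, a limit of the assay. Compound 2 `O=C(O)CC/C=C\CC1COC(c2ccc([N+](=O)[O-])cc2)OC1c1cccnc1` in this assay gives 13000 nM. Compound 3 `CC(C)(Oc1ccccc1F)C1OCC(C/C=C\CCC(=O)O)C(c2cccnc2)O1` in this assay gives < 1000 nM, likewise a limit of the assay.

Compound 3 therefore stands at the limit of < 1000 nM in this assay, at which 1 of the 3 values shown sits, so the numbers shown place it only at that boundary and not at a definite point. Among the measured compounds shown here, the one measured step, an at least 7.6-fold lower number from compound 1 to compound 2 (0.88 log units; beyond the scatter), concerns the substituent on the aromatic carbon and says nothing about the position changed here. Compound 4 `CC(C)(Cc1ccccc1)C1OCC(C/C=C\CCC(=O)O)C(c2cccnc2)O1` differs from compound 3 by benzyl in place of 2-fluorophenoxy on a saturated chain carbon bound to two saturated chain carbons and a saturated ring carbon. For the measured compounds named here, no measured step bears on this exchange, and compound 3 itself is known only as a limit. Compound 4 is accordingly expected to stay close to compound 3, with a step that the limit leaves unreadable from compound 3 to compound 4 that may not rise beyond the scatter. The estimate for compound 4 in this assay is 800 nM, within 150 nM to 4000 nM.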

Compound 4, half-maximal inhibitory concentration: 13000 nM
Compound 4: middle estimate off by 16-fold (1.21 log units), on the low side, outside the stated range (above it).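

Benzyl in place of 2-fluorophenoxy on this saturated chain carbon gives an at least 13-fold higher number from compound 3 to compound 4 (1.11 log units; beyond the scatter), so in this assay the two groups are not interchangeable here, and the size of the step is only a lower bound: the limit of < 1000 nM in this assay, at which 1 of the 4 values shown sits.

The 1-benzyl-1-methylethyl group of compound 4 and the 4-nitrophenyl group of compound 2 stand level on the saturated ring carbon, with no change at the digits printed from compound 2 to compound 4 (within the scatter). Against the 4-cyanophenyl group the same exchange gives an at least 7.6-fold lower number from compound 1 to compound 4 (0.88 log units; beyond the scatter), and this step is likewise open-ended: the limit of > 100000 nM in this assay, at which 1 of the 4 values shown sits.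

The compounds shown leave open whether the gap follows the ether oxygen or the fluorine of 2-fluorophenoxy, and so whether a plain phenoxy group would read like compound 3 or like compound 4. As far as these compounds go, how far the true value of compound 3 lies past its limit also remains open.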